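This account rests on a few compounds, and the source may have more. Where it says the series, first, only, none or still open, it means among the compounds named here.

Of the compounds shown here, three from one series have been tested in a functional assay (thoracic aorta) for inhibition, with Rattus norvegicus as the target; a lower number here means a stronger inhibitor, a higher number a weaker inhibitor. Compound 1 `O=C(O)c1cc(CCCCCNS(=O)(=O)c2ccccc2)c2cccccc1-2` gives 840 nM in this assay. Compound 2 `O=C(O)c1cc(CCCCCCNS(=O)(=O)c2ccccc2)c2cccccc1-2` gives 140 nM. Compound 3 `CC(C)c1ccc2c(CCCCCNS(=O)(=O)c3ccccc3)cc(C(=O)O)c-2cc1` gives 120 nM. Compound 3 differs from compound 1 in one place only, (isopropyl in place of hydrogen on an aromatic carbon), and this single change brings a 7.0-fold lower number from compound 1 to compound 3 (0.85 log units; beyond the scatter). Compound 2 differs from compound 1 in more than one place, and the difference between the two cores is not broken down here. Compound 4 `CC(C)c1cccc2c(CCCCCCNS(=O)(=O)c3ccccc3)cc(C(=O)O)c-2c1` has not yet been measured. It stands to compound 2 as compound 3 stands to compound 1: the change is isopropyl in place of hydrogen on an aromatic carbon, the same change made at the same kind of place on the shared core. Because the earlier step was a 7.0-fold lower number from compound 1 to compound 3 (0.85 log units; beyond the scatter), a step in the same direction is expected here, kept somewhat more cautious since a single earlier example is all that supports it, so the expected step is a 4.0-fold lower number from compound 2 to compound 4 (0.60 log units; beyond the scatter). Compound 4 is therefore estimated at 35 nM in this assay, with a likely range from 12 nM to 120 nM.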

Compound 4, half-maximal inhibitory concentration: 920 nM
Beside the measured number, compound 4's estimate is 26-fold (1.42 log units) below it; measured number outside the range, above it.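

In this assay isopropyl in place of hydrogen on an aromatic carbon brings a 6.6-fold higher number from compound 2 to compound 4 (0.82 log units; beyond the scatter) on the core of compound 2. The change therefore does not carry over between these two cores, and its effect runs in opposite directions on them: the same change on two cores in this assay, a 7.0-fold lower number (0.85 log units; beyond the scatter) from compound 1 to compound 3 and a 6.6-fold higher number (0.82 log units; beyond the scatter) from compound 2 to compound 4, 46-fold (1.66 log units) apart, beyond the scatter of two such steps. This shows that the outcome of the change depends on the core that receives it, so a step seen on one core is a poor guide to the other, but two pairs cannot show which difference between the cores is responsible or why the direction reverses.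

The compounds shown leave open whether a smaller group such as methyl, or a halogen such as chlorine, in place of that hydrogen would follow the step seen on the core of compound 1 or the one seen on the core of compound 2. Further pairs on each core would also be needed to tell whether either step holds beyond a single example.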